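The source may hold more compounds than are shown below. What is called first, only, known or untested is meant among the compounds shown, and "the series" means these compounds.

Measured compounds:
- compound 1, `COC1CCN(C(=O)N2CC(c3nc(-c4cccc(Cl)c4)no3)C2)CC1`: > 10000 nM
- compound 2, `Cc1cccc(-c2noc(C3CN(C(=O)c4cccc(F)c4)C3)n2)c1`: > 10000 nM

The account follows compound 1, whose structure is `COC1CCN(C(=O)N2CC(c3nc(-c4cccc(Cl)c4)no3)C2)CC1`. In an assay on HEK293 cells for positive allosteric modulation of metabotropic glutamate receptor 5 (Homo sapiens), read by FLIPR (a higher number here means that more compound is needed for the effect, a lower number that less compound is needed), compound 1 gives > 10000 nM, which is a limit of the assay rather than a number. Compound 2, with the structure `Cc1cccc(-c2noc(C3CN(C(=O)c4cccc(F)c4)C3)n2)c1`, gives in this assay the value > 10000 nM, again a limit and not a number. Compound 1 therefore stands at the limit of > 10000 nM in this assay, at which 2 of the 2 values shown sit, and nothing measured here places it any more precisely than that.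

Compound 3, with the structure `COC1CCCN(C(=O)N2CC(c3nc(-c4cccc(Cl)c4)no3)C2)C1`, has not yet been measured. It differs from compound 1 in one place: 3-methoxypiperidin-1-yl in place of 4-methoxypiperidin-1-yl on a carbonyl carbon. The atoms are the same; only their arrangement within the ring that carries the methoxy group changes.

Going by the values given here, no pair of measured compounds that differ in one place is available, so the size of this step can only be expected, not read from a neighbour. With both measured values sitting at the limit, the step in this assay is expected to be none beyond the scatter, with compound 3 most likely remaining at the limit. Compound 3 is expected to give 20000 nM, within a range from 5000 nM to 80000 nM. The step this implies, a step that the limit leaves unreadable from compound 1 to compound 3, is an expectation only.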

Compound 3, half-maximal effective concentration: > 10000 nM
Compound 3 gave a limit, no number (the forecaster's own chance of this, stated with the estimate: 85%); the middle value lies beyond the limit too.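

In this assay compound 3 gives > 10000 nM as a limit, not a number. Going by these compounds alone, compound 1 also sits at a limit, so no step from compound 1 to compound 3 can be read. The compounds shown leave open whether 3-methoxypiperidin-1-yl and 4-methoxypiperidin-1-yl differ at all here, and what actual value either compound would have.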